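Replacing 2-methylprop-1-en-1-yl with 3-nitrophenyl

The source may hold more compounds than are shown below. What is called first, only, known or untested is meant among the compounds shown, and "the series" means these compounds.

Measured in a functional assay on PA-1 cells (Homo sapiens) for cytotoxicity, read by colony formation; on this read-out higher numbers stand for weaker inhibition and lower numbers for stronger inhibition:
- compound 1 `CCC(=O)OC[C@H]1O[C@@H](O[C@@H]2OC=C(C(=O)OC)[C@H]3C[C@H](OC(C)=O)[C@H](C)[C@@H]23)[C@H](OC(C)=O)[C@@H](OC(C)=O)[C@@H]1OC(C)=O`: 2.85 ug/mL
- compound 2 `CCCCCCCCCCCC(=O)OC[C@H]1O[C@@H](O[C@@H]2OC=C(C(=O)OC)[C@H]3C[C@H](OC(C)=O)[C@H](C)[C@@H]23)[C@H](OC(C)=O)[C@@H](OC(C)=O)[C@@H]1OC(C)=O`: 0.42 ug/mL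
- compound 3 `COC(=O)C1=CO[C@@H](O[C@@H]2O[C@H](COC(=O)C=C(C)C)[C@@H](OC(C)=O)[C@H](OC(C)=O)[C@H]2OC(C)=O)[C@@H]2[C@@H](C)[C@@H](OC(C)=O)C[C@H]12`: 1.84 ug/mL

Compound 3 cannot be told apart from its nearest neighbour, with a 1.5-fold lower number from compound 1 to compound 3 (0.19 log units; within the scatter). Compound 2 stands apart, with a 6.8-fold lower number from compound 1 to compound 2 (0.83 log units; beyond the scatter) and a 4.4-fold higher number from compound 2 to compound 3 (0.64 log units; beyond the scatter). Compound 4 `COC(=O)C1=CO[C@@H](O[C@@H]2O[C@H](COC(=O)c3cccc([N+](=O)[O-])c3)[C@@H](OC(C)=O)[C@H](OC(C)=O)[C@H]2OC(C)=O)[C@@H]2[C@@H](C)[C@@H](OC(C)=O)C[C@H]12` has not been measured, and it carries 3-nitrophenyl in place of 2-methylprop-1-en-1-yl on a carbonyl carbon.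

All three measured steps change the group at this carbonyl carbon, but none brings in an aromatic ring, so they guide only loosely. Only the long chain of compound 2 moved the number beyond the scatter, so no step beyond the scatter is expected in this assay. The estimate means an expected 1.2-fold lower number from compound 3 to compound 4 (0.09 log units; within the scatter). For compound 4 the estimated value is 1.5 ug/mL, with an expected range from 0.5 ug/mL to 4.5 ug/mL.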

Compound 4, half-maximal inhibitory concentration: 2.65 ug/mL
The estimate for compound 4 lay 1.8-fold (0.25 log units) below the measured number; the range from low to high includes it.
By their numbers in this assay, from the lowest: compound 2; then compounds 3, 4 and 1 (each within the scatter of the next).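

In this assay, an aromatic ring on this carbonyl carbon reads no differently from the smaller groups: 3-nitrophenyl stays within the scatter of 2-methylprop-1-en-1-yl (a 1.4-fold higher number from compound 3 to compound 4 (0.16 log units; within the scatter)) and of ethyl (a 1.1-fold lower number from compound 1 to compound 4 (0.03 log units; within the scatter)). Undecyl remains the one group that stands apart, now also from the aromatic ester (a 6.3-fold higher number from compound 2 to compound 4 (0.80 log units; beyond the scatter)). No measurement is available to explain this result. The compounds shown leave open how an amine or a carboxylic acid on this carbonyl carbon would read, and at what length between ethyl and undecyl a chain begins to lower the number.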